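A Hydroxy Substituent on the Pendant Phenyl Ring

The compounds below may be only part of what the source reports. "The series", "measured", "known", "first", "only" and "open" are said of these compounds alone.

Compound 1 `c1ccc(Cn2cc(-c3ccccc3)c3c2CCNC3)cc1` gives 220 nM in an assay on HEK293 cells for displacement of a labelled ligand from 5-hydroxytryptamine receptor 7 (Rattus norvegicus), with a stated time of 60 min (a higher number here means a weaker inhibitor, a lower number a stronger inhibitor), the lowest number of the three measured compounds. Compound 2 `O=[N+]([O-])c1ccc(-c2cn(Cc3ccccc3)c3c2CNCC3)cc1` gives 450 nM, and compound 3 `CC(C)(C)c1ccc(-c2cn(Cc3ccccc3)c3c2CNCC3)cc1` gives 10000 nM. Compound 4 `Oc1ccc(-c2cn(Cc3ccccc3)c3c2CNCC3)cc1` differs from compound 1 by hydroxy in place of hydrogen on an aromatic carbon. Two measured steps place a new group at the same aromatic carbon: a 2.0-fold higher number from compound 1 to compound 2 (0.31 log units; beyond the scatter), and a 45-fold higher number from compound 1 to compound 3 (1.66 log units; beyond the scatter). Both substitutions raised the number, one modestly and one strongly. A hydroxy group is the smallest of these replacements, so a modest rise beyond the scatter is expected, in the direction of weaker inhibition. The step is estimated as a 1.9-fold higher number from compound 1 to compound 4 (0.28 log units; within the scatter). Compound 4 is therefore expected to give about 420 nM, within a range from 160 nM to 1200 nM.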

Compound 4, inhibition constant: 10000 nM
For compound 4 the middle estimate is 24-fold (1.38 log units) below the measured one; the measured number lies above the stated range.
By their numbers in this assay, from the lowest: compound 1; then compound 2; then compounds 3 and 4 (each within the scatter of the next).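

Hydroxy, with its single heavy atom, gives a 45-fold higher number from compound 1 to compound 4 (1.66 log units; beyond the scatter) in this assay, and against tert-butyl it shows no change at the digits printed from compound 3 to compound 4 (within the scatter), so at this position a large step does not require a large group. Nitro remains the one group of the three near the unsubstituted compound, with hydroxy giving a 22-fold higher number from compound 2 to compound 4 (1.35 log units; beyond the scatter). Nothing available here accounts for this difference between the groups.

On these data alone, whether a methoxy group or an amine at the same carbon would track nitro or hydroxy remains open. Also open, as far as these compounds go, is whether hydroxy elsewhere on this ring would give a step of similar size.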